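From acetyl to a larger chain on compound 2

The source may hold more compounds than are shown below. What is called first, only, known or untested is meant among the compounds shown, and "the series" means these compounds.

Measured in an ADME assay on Vero cells (Chlorocebus sabaeus) for cytotoxicity, read by MTT assay, with a stated time of 96 h; on this read-out higher numbers stand for lower toxicity in this test and lower numbers for higher toxicity in this test:
- compound 1 `COc1ccc(-c2nc3cc(C(C)=O)ccc3n2C2CCCCC2)cc1`: 30000 nM
- compound 2 `COc1ccc(-c2nc3cc(C(C)=O)ccc3n2C2CCCCC2)c(OC)c1`: 70000 nM

Of the two measured compounds, compound 2 gives the higher number, 70000 nM. Compound 3 `COc1ccc(-c2nc3cc(/C(C)=N/NC(N)=O)ccc3n2C2CCCCC2)c(OC)c1` keeps the rest of compound 2 and replaces its acetyl, on an aromatic carbon: a group of 7 heavy atoms (3 carbon, 3 nitrogen, 1 oxygen; no ring) in place of a group of 3 heavy atoms (2 carbon, 1 oxygen; no ring), on an aromatic carbon. Among the compounds with values here, only one measured step is available, a 2.3-fold higher number from compound 1 to compound 2 (0.37 log units; beyond the scatter), a modest one. It concerns a methoxy in place of hydrogen, not the acetyl, so it bears on this change only indirectly and serves as a rough guide to how far the numbers can move within the series. Within the data shown here, no measured compound alters the acetyl, and the data give no direction for this change. The step expected is a 1.2-fold lower number from compound 2 to compound 3 (0.07 log units; within the scatter), with no change beyond the scatter as the working assumption. For compound 3 the estimated value is 60000 nM, with an expected range of 20000 nM to 150000 nM.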

Compound 3, half-maximal cytotoxic concentration: 20000 nM
Compound 3: the middle estimate sits 3.0-fold (0.48 log units) above what was measured, within the range that was stated.
By their numbers in this assay, from the lowest: compounds 3 and 1 (each within the scatter of the next); then compound 2.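

In this assay, the acetyl position turns out to be sensitive: exchanging acetyl for the chain of 7 heavy atoms gives a 3.5-fold lower number from compound 2 to compound 3 (0.54 log units; beyond the scatter), a modest step. On this aromatic carbon the number moves downward, towards higher toxicity in this test, whereas the methoxy step, a 2.3-fold higher number from compound 1 to compound 2 (0.37 log units; beyond the scatter), ran upward at a different place on the core. Nothing measured on these compounds offers an explanation for the downward step.

Open, from the compounds shown here alone, is which part of the entering chain goes with the lower number, and whether an amine, a carboxylic acid or a simple oxime on the same aromatic carbon would move it the same way. Also open, going by these compounds, is whether the same exchange gives a similar step on the core of compound 1, which lacks the added methoxy.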